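A Third Methoxy Group on the Benzylamine Side Chain

A few compounds are considered here, and "the series" means these few. Any claim that something is new, unique, unknown or untested is made for them only; others in the source may bear on it.

Compound 1, `Nc1cc(N)c2nc(-c3ccccc3)c(Oc3ccc(Cl)c(Cl)c3)nc2c1`: in a functional assay on NCI-H226 cells (Homo sapiens) for inhibition, read by sulforhodamine B assay, with a stated time of 48 h (on this read-out lower numbers stand for stronger inhibition of growth and higher numbers for weaker inhibition of growth), compound 1 gives 15100 nM.
Compound 2, `Nc1cc(N)c2nc(-c3ccccc3)c(NCc3ccc(Cl)c(Cl)c3)nc2c1`: in this assay compound 2 gives 22400 nM.
Compound 3, `COc1ccc(CNc2nc3cc(N)cc(N)c3nc2-c2ccccc2)cc1OC`: in this assay compound 3 gives 14500 nM.

Compound 3 has the lowest of the three numbers, but its gap to compound 1 and its gap to compound 2 both lie within the scatter, so the three compounds cannot be told apart on these values. Within the data shown here, the one step between measured compounds that differ in a single place, a 1.5-fold lower number from compound 2 to compound 3 (0.19 log units; within the scatter), was itself within the scatter, even though it exchanged both substituents on that ring.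

Compound 4, `COc1cc(CNc2nc3cc(N)cc(N)c3nc2-c2ccccc2)cc(OC)c1OC`, differs from compound 3 by methoxy in place of hydrogen on an aromatic carbon, a methoxy in place of hydrogen on an aromatic carbon. Among the measured compounds shown here, no measured step adds or removes a single methoxy group, so nothing bears on this change directly. For the measured compounds named here, the only step that touches the same ring, a 1.5-fold lower number from compound 2 to compound 3 (0.19 log units; within the scatter), stayed within the scatter despite a larger exchange, which gives no ground to expect a larger effect from a smaller one.

Compound 4 is therefore expected to give about 15000 nM, in the range 6000 nM to 40000 nM. The expected step, a 1.0-fold higher number from compound 3 to compound 4 (0.01 log units; within the scatter), amounts to no change beyond the scatter.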

Compound 4, concentration for 50% growth inhibition: 10000 nM
For compound 4 the middle estimate is 1.5-fold (0.18 log units) above the measured one, within the range that was stated.
By their numbers in this assay, from the lowest: compounds 4, 3, 1 and 2 (each within the scatter of the next, the first and the last beyond it).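

Adding one methoxy group to this ring, at the place ortho to a methoxy group and meta to a large group, gives a 1.5-fold lower number from compound 3 to compound 4 (0.16 log units; within the scatter) in this assay, the first step in which a single group on this ring changes alone. The earlier step had exchanged both substituents on the ring together, so it could not show what one added group does; here a methoxy in place of hydrogen on an aromatic carbon also leaves the number within the scatter, which means that compound 3 and compound 4 cannot be told apart on these values. Nothing available here offers an explanation for this result.

The compounds shown leave open whether a group other than methoxy at this same place, such as an amine, a carboxylic acid or a hydroxy group, would shift the number beyond the scatter. They also leave open whether a longer chain linking this ring to the nitrogen on the shared core would do so with the three methoxy groups kept in place.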